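The source may report more compounds than this note shows. Statements on the series, on what has been measured and on what is new or still open speak of the compounds shown alone.

Compound 1 `Cc1cc(Cl)c(S(C)(=O)=O)cc1C(=O)N=C(N)N`: 25 nM
Compound 2 `Cc1c(C(=O)N=C(N)N)cc(S(C)(=O)=O)c(Cl)c1C`: 58 nM
Compound 3 `CS(=O)(=O)c1cc(C(=O)N=C(N)N)ccc1C#N`: 140 nM

In a functional assay for inhibition of sodium/hydrogen exchanger (Oryctolagus cuniculus) (a lower number here means a stronger inhibitor, a higher number a weaker inhibitor), compound 1 gives 25 nM, while compound 3 gives 140 nM, the highest of the three numbers. The difference between the core of compound 1 and the core of compound 3 is not broken down here. Compound 2 carries one change relative to compound 1, (methyl in place of hydrogen on an aromatic carbon), and the result was a 2.3-fold higher number from compound 1 to compound 2 (0.37 log units; beyond the scatter).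

Compound 4 `Cc1cc(C#N)c(S(C)(=O)=O)cc1C(=O)N=C(N)N` has not been measured. It differs from compound 3 by methyl in place of hydrogen on an aromatic carbon, the same kind of change, but the surroundings differ: in compound 2 the methyl sits ortho to a chloro group and ortho to a methyl group, meta to a group of 6 heavy atoms and meta to a methylsulfonyl group, whereas in compound 4 it sits ortho to a group of 6 heavy atoms, meta to a cyano group and para to a methylsulfonyl group. Because compound 2 showed a 2.3-fold higher number from compound 1 to compound 2 (0.37 log units; beyond the scatter), a step of similar direction and modest size is expected here, a 1.6-fold higher number from compound 3 to compound 4 (0.20 log units; within the scatter), with wider uncertainty given the different surroundings. Compound 4 is therefore estimated at 220 nM, between 80 nM and 600 nM.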

Compound 4, half-maximal inhibitory concentration: 70 nM
For compound 4 the middle estimate is 3.1-fold (0.50 log units) above the measured one; the measured number lies below the stated range.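

Putting a methyl in place of hydrogen on an aromatic carbon does not carry over as a fixed step from one core to another in this assay, and the two examples clearly disagree: the same change on two cores in this assay, a 2.3-fold higher number (0.37 log units; beyond the scatter) from compound 1 to compound 2 and a 2.0-fold lower number (0.30 log units; within the scatter) from compound 3 to compound 4, 4.6-fold (0.67 log units) apart, beyond the scatter of two such steps

Read alone, the new methyl step is a 2.0-fold lower number from compound 3 to compound 4 (0.30 log units; within the scatter), too small to count as a real change, while cyano in place of chloro, with the rest of the molecule kept, gives a 2.8-fold higher number from compound 1 to compound 4 (0.45 log units; beyond the scatter). Two pairs show that the methyl step depends on its setting, but they cannot show which feature of that setting matters, as the surroundings of the methyl differ in more than one way.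

On these data alone, it remains open how a longer chain such as ethyl, or a methoxy group, would behave at these places. A third core could also show whether either methyl step is the more typical.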